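The compounds below may be only part of what the source reports. "The series", "measured", "known", "first", "only" and "open" are said of these compounds alone.

Measured compounds in an ADME assay on HCT-116 cells (Homo sapiens) for cytotoxicity, read by MTT assay, with a stated time of 72 h; a higher number here means a weaker inhibitor, a lower number a stronger inhibitor:
compound 1 `CCOc1ccc(NC(=O)c2cccc(/C=C3\CC(=O)N(Cc4ccccc4)C3=O)c2)cc1` gives 41700 nM.
compound 2 `O=C(NCC1CCCCC1)c1cccc(/C=C2\CC(=O)N(c3ccccc3)C2=O)c1` gives > 100000 nM, which is a limit of the assay and not a number.
compound 3 `CCOc1ccc(NC(=O)c2cccc(/C=C3\CC(=O)N(c4ccccc4)C3=O)c2)cc1` gives 84800 nM.

Compound 3 holds the highest of the two numbers; the nearest number is that of compound 1, with a 2.0-fold higher number from compound 1 to compound 3 (0.31 log units; beyond the scatter). Compound 2 sits at the limit of > 100000 nM in this assay, at which 1 of the 3 values shown sits, so the step of an at least 1.1-fold lower number from compound 2 to compound 3 (0.07 log units; that floor lies within the scatter) gives only a floor, and that floor lies within the scatter. Compound 4 `COc1ccc(NC(=O)c2cccc(/C=C3\CC(=O)N(c4ccccc4)C3=O)c2)cc1` differs from compound 3 by hydrogen in place of methyl on a saturated chain carbon bound to an oxygen on an aromatic ring. Within the data shown here, neither measured step bears on this change: the step from compound 1 concerns the amide-type nitrogen in the ring, the step from compound 2 the amide-type nitrogen outside it, and no measured pair varies the ethoxy group itself. Among the measured compounds shown here, with no step to lean on, the expected change in this assay is none beyond the scatter, in either direction. Compound 4 is therefore estimated at 80000 nM, with a range of 40000 nM to 160000 nM, meaning an expected step of a 1.1-fold lower number from compound 3 to compound 4 (0.03 log units; within the scatter). The upper end of that range reaches the limit of the assay, so a limit-only read is a real possibility.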

Compound 4, half-maximal inhibitory concentration: > 100000 nM
Compound 4: a limit, no number; the forecaster's own chance of this, stated with the estimate: 30%; middle value at least 1.2-fold (0.09 log units) from the limit.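

In this assay compound 4 gives > 100000 nM, which is a limit of the assay and not a number. Among these compounds, the change from ethoxy to methoxy is the first variation at this position, and it can be read only as a floor, an at least 1.1-fold higher number from compound 3 to compound 4 (0.07 log units; that floor lies within the scatter), so it shows no gain in potency but fixes no size for any loss. The step from compound 2 to compound 4 cannot be read because both values are limits: the limit of > 100000 nM in this assay, at which 2 of the 4 values shown sit.

As far as these compounds go, whether a propoxy chain or a hydroxyl group at the same place would return a number remains open. Also open, from the compounds shown here alone, is whether benzyl on the amide-type nitrogen in the ring would bring the 4-methoxyphenyl compound within the range of the assay.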